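The compounds below may be only part of what the source reports. "The series", "measured", "known", "first", "only" and "open" are said of these compounds alone.

In a functional assay on the whole organism for inhibition, with Rattus norvegicus as the target (on this read-out lower numbers stand for an effect already at smaller amounts and higher numbers for an effect only at larger amounts of compound), compound 3 `CC1CC/C(=N\Nc2ccccc2I)c2ncc(C(=O)O)c(=O)n21` gives only a limit, > 1000 umol/kg. Compound 1 `CC1CC/C(=N\Nc2cccc(Cl)c2)c2ncc(C(=O)O)c(=O)n21` likewise reaches only a limit, > 100 umol/kg. Compound 2 `CC1CC/C(=N\Nc2ccc(Br)cc2)c2ncc(C(=O)O)c(=O)n21` also shows a limit, > 1000 umol/kg. The steps among these three compounds, a step that the two limits leave unreadable from compound 1 to compound 2, a step that the two limits leave unreadable from compound 1 to compound 3 and a step that the two limits leave unreadable from compound 2 to compound 3, therefore cannot be sized; the limit of > 100 umol/kg in this assay, at which 1 of the 3 values shown sits, and the limit of > 1000 umol/kg in this assay, at which 2 of the 3 values shown sit, mark where the values sit. Compound 4 `CC1CC/C(=N\Nc2ccc(O)cc2)c2ncc(C(=O)O)c(=O)n21` differs from compound 3 by 4-hydroxyphenyl in place of 2-iodophenyl on an amine nitrogen. Among the compounds with values here, no measured step bears on this change, and none of the three halogen-bearing compounds gave a number, so no direction can be read from them. Compound 4 is expected to give 1000 umol/kg, within 300 umol/kg to 3000 umol/kg, most likely again only a limit. This estimate means an expected step of a number no higher from compound 3 to compound 4 (the limit leaves the size open).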

Compound 4, dose for 50% inhibition: > 100 umol/kg
Compound 4: a limit, no number; the forecaster's own chance of this, stated with the estimate: 80%; the middle value is on the limit's open side.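

Compound 4, like compound 1, compound 2 and compound 3, gives only a limit in this assay, so no step among these four compounds can be read. The compounds shown leave open how the groups on the amine nitrogen would rank, and whether any of them gives a measurable dose.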